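The compounds below may be only part of what the source reports. "The series", "measured", "known", "first", "only" and "open" are said of these compounds alone.

Working notes on a small set of compounds sharing the core of compound 1 `FC(F)(F)c1ccc2[nH]c(-c3ccccc3)nc2c1`. In a functional assay for antagonist activity at Neuropeptides B/W receptor type 1 (Homo sapiens), read by cAMP accumulation (a lower number here means a stronger inhibitor, a higher number a weaker inhibitor), compound 1 gives 1200 nM, the lowest of the two numbers reported. Compound 3 `Cc1ccc(-c2nc3cc([N+](=O)[O-])ccc3[nH]2)cc1C` gives 1380 nM in this assay, and the gap between compound 3 and compound 1 lies within the scatter, so neither is set apart from the other. Compound 2 `O=[N+]([O-])c1ccc2[nH]c(-c3ccc(C(F)(F)F)cc3)nc2c1` gives > 31600 nM in this assay, which is a limit of the assay and not a number (the limit of > 31600 nM in this assay, at which 1 of the 3 values shown sits). No pair of these compounds differs in one place only, so no single structural step has yet been measured.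

Compound 4 `NCc1ccc(-c2ccc(-c3nc4cc(C(F)(F)F)ccc4[nH]3)cc2)cc1` is the next compound to be measured in this assay. Relative to compound 1 it carries 4-(aminomethyl)phenyl in place of hydrogen on an aromatic carbon. Among the compounds with values here, nothing measured here speaks to the effect of such a change; no measured pair differs in this way. The expectation for compound 4 is a moderate step toward a lower number, a 2.0-fold lower number from compound 1 to compound 4 (0.30 log units; within the scatter), though a result with no change beyond the scatter would also be consistent with what is known. Compound 4 is therefore estimated at 600 nM, with a range from 150 nM to 3000 nM.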

Compound 4, half-maximal inhibitory concentration: 720 nM
Compound 4: the middle estimate sits 1.2-fold (0.08 log units) below what was measured; the range from low to high includes it.
By their numbers in this assay, from the lowest: compounds 4, 1 and 3 (each within the scatter of the next). At a limit, above all of these: compound 2.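

In this assay, within the data shown here, the first single-place step is the addition of 4-(aminomethyl)phenyl on an aromatic carbon, para to a large group, and it reads as a 1.7-fold lower number from compound 1 to compound 4 (0.22 log units; within the scatter) for this change. This position on the terminal ring of compound 1 therefore accepts a large addition, with a further six-membered aromatic ring and a primary amine, without the number leaving the scatter, so the step sets compound 4 apart from compound 1 neither way. None of the data shown gives a reason for this outcome, and the limit recorded for compound 2 does not bear on this step.

The step does not separate the part of the added ring from that of the amine: a plain phenyl at this position, or a carboxylic acid or a longer aminoalkyl chain in place of aminomethyl, would address that question. Going by these compounds, how compound 2 and compound 3 relate to the rest of the series also stays open, as each differs from compound 1 and compound 4 in more than one place.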